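Swapping the benzyl group on the ring nitrogen for a thiourea

This account rests on a few compounds, and the source may have more. Where it says the series, first, only, none or still open, it means among the compounds named here.

Compound 1, `Cc1ccc(C(=O)Nc2sc3c(c2C(N)=O)CCN(Cc2c(Cl)cccc2Cl)C3)cc1`: 12300 nM in a functional assay on MKN-74 cells (Homo sapiens) for antiproliferative activity, with a stated time of 24 h; a higher number here means a weaker inhibitor, a lower number a stronger inhibitor
Compound 2, `NC(=O)c1c(NC(=O)c2ccccc2F)sc2c1CCN(Cc1c(Cl)cccc1Cl)C2`: 7430 nM in this assay
Compound 3, `NC(=O)c1c(NC(=O)c2cccc([N+](=O)[O-])c2)sc2c1CCN(Cc1c(Cl)cccc1Cl)C2`: 13500 nM in this assay

Compound 2 shows the lowest number of the three, but the gaps to its neighbours are small: a 1.7-fold lower number from compound 1 to compound 2 (0.22 log units; within the scatter), and a 1.8-fold higher number from compound 2 to compound 3 (0.26 log units; within the scatter). The third comparison, a 1.1-fold higher number from compound 1 to compound 3 (0.04 log units; within the scatter), is equally small. All three measured changes sit on the aryl group attached to the carbonyl carbon of the amide, and none of them moved the number beyond the scatter.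

Compound 4, `NC(=O)c1c(NC(=O)c2ccccc2F)sc2c1CCN(C(=S)Nc1ccccc1Cl)C2`, changes a different part of the molecule: a group of 10 heavy atoms (7 carbon, 1 nitrogen, 1 sulfur, 1 chlorine; one six-membered aromatic ring of carbon only) in place of a group of 9 heavy atoms (7 carbon, 2 chlorine; one six-membered aromatic ring of carbon only), on an amine nitrogen in a ring. Among the compounds with values here, no measured pair touches this position, so the three steps give no direct guidance, only the observation that the shared core has so far tolerated changes without large shifts. For compound 4 the number is therefore expected to stay close to that of compound 2, with wide uncertainty in both directions, giving an estimated step of a 1.3-fold higher number from compound 2 to compound 4 (0.13 log units; within the scatter). The estimate for compound 4 in this assay is 10000 nM, with a range from 2000 nM to 50000 nM.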

Compound 4, half-maximal inhibitory concentration: 11100 nM
The estimate for compound 4 lay 1.1-fold (0.05 log units) below the measured number, and the stated range covers the measured number.
By their numbers in this assay, from the lowest: compounds 2, 4, 1 and 3 (each within the scatter of the next).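

Within the data shown here, this is the first change at the amine nitrogen in the ring, and in this assay replacing the 2,6-dichlorobenzyl group with a thiourea carrying a chlorophenyl ring gives a 1.5-fold higher number from compound 2 to compound 4 (0.17 log units; within the scatter). The position therefore takes a very different link without the number leaving the scatter: the entering group brings a double bond outside aromatic rings, a hydrogen-bond donor and a hydrogen-bond acceptor, and the group it replaces has no donor or acceptor. No supporting measurement bears on this result.

On these data alone, this single pair carries the 2-fluorophenyl amide, so it remains open whether the same swap behaves alike with the 4-methylphenyl or 3-nitrophenyl amide. A urea, with oxygen in place of the sulfur, or a longer chain ending in an amine or a carboxylic acid on that nitrogen could show whether this position can move the number at all.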